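The source may hold more compounds than are shown below. What is called first, only, known or untested is meant among the compounds shown, and "the series" means these compounds.

Compound 2 `CCCCCCCNc1nc2cc(-c3ccc(C)cc3)sc2c(=O)[nH]1` stands highest of the two numbers measured in an ADME assay on HepG2 cells (Homo sapiens) for cytotoxicity, read by MTT assay, with a stated time of 72 h (on this read-out higher numbers stand for lower toxicity in this test and lower numbers for higher toxicity in this test), giving 6800 nM. Compound 1 `CCCCCNc1nc2cc(-c3ccc(C)cc3)sc2c(=O)[nH]1` gives 4200 nM in this assay, and the step of a 1.6-fold higher number from compound 1 to compound 2 (0.21 log units; within the scatter) is within the scatter. Compound 3 `CCCCN(C)c1nc2cc(-c3ccc(C)cc3)sc2c(=O)[nH]1` differs from compound 2 in one place: butyl(methyl)amino in place of heptylamino on an aromatic carbon. Within the data shown here, the only measured step that bears on this change is the chain lengthening from compound 1 to compound 2, and it stayed within the scatter, so no step beyond the scatter is expected here in this assay. Compound 3 is therefore estimated at 5000 nM, with a range from 2000 nM to 12000 nM, an expected step of a 1.4-fold lower number from compound 2 to compound 3 (0.13 log units; within the scatter).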

Compound 3, half-maximal cytotoxic concentration: 3000 nM
Beside the measured number, compound 3's estimate is 1.7-fold (0.22 log units) above it, within the range that was stated.
By their numbers in this assay, from the lowest: compounds 3, 1 and 2 (each within the scatter of the next, the first and the last beyond it).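

In this assay, among these compounds, the swap on this aromatic carbon gives a 2.3-fold lower number from compound 2 to compound 3 (0.36 log units; beyond the scatter), the first step in this set beyond the scatter, so the heptylamino and butyl(methyl)amino groups can be told apart here. Replacing pentylamino with butyl(methyl)amino gives only a 1.4-fold lower number from compound 1 to compound 3 (0.15 log units; within the scatter), so the size of the effect depends on which group leaves. Nothing available explains either step. From the compounds shown here alone, it remains open how a ring amine such as morpholine or a chain longer than heptylamino would behave at this position.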